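Imidazoline aryl amines: swapping the ortho isoxazole

A few compounds are considered here, and "the series" means these few. Any claim that something is new, unique, unknown or untested is made for them only; others in the source may bear on it.

Measured so far:
- compound 1, `Cc1cc(-c2ccccc2NCC2=NCCN2)on1`: 38.9 nM
- compound 2, `FC(F)(F)c1cccnc1-c1ccccc1NCC1=NCCN1`: 676 nM

In a functional assay for activation of Alpha-1A adrenergic receptor (Homo sapiens), read by calcium flux (a higher number here means that more compound is needed for the effect, a lower number that less compound is needed), compound 1 gives the lowest of the two numbers. For the measured compounds named here, the only comparison available is to compound 2, which lies at a higher number, a gap beyond the usual scatter, so compound 1 stands clearly apart from compound 2 on this readout.

Compound 3, `CO/N=C(\C)c1ccccc1NCC1=NCCN1`, keeps the shared core of compound 1 and alters one group. The change, (a group of 5 heavy atoms (3 carbon, 1 nitrogen, 1 oxygen; no ring) in place of a group of 6 heavy atoms (4 carbon, 1 nitrogen, 1 oxygen; one five-membered aromatic ring with 2 hetero atoms), on an aromatic carbon), replaces the five-membered aromatic ring with an open group carrying one double bond outside aromatic rings, at the same place on the six-membered carbon ring.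

Going by the values given here, no step between measured compounds has been recorded for this change, so the expectation rests on the two values above alone. The step of a 3.9-fold higher number from compound 1 to compound 3 (0.59 log units; beyond the scatter) is expected to be a moderate rise, beyond the scatter but well short of the gap to compound 2. Compound 3 is estimated at 150 nM in this assay, with a range of 40 nM to 600 nM.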

Compound 3, half-maximal effective concentration: 20.9 nM
Beside the measured number, compound 3's estimate is 7.2-fold (0.86 log units) above it; measured number outside the range, below it.
By their numbers in this assay, from the lowest: compounds 3 and 1 (each within the scatter of the next); then compound 2.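

In this assay the open group in place of the 3-methyl-1,2-oxazol-5-yl group gives a 1.9-fold lower number from compound 1 to compound 3 (0.27 log units; within the scatter) and so leaves the two compounds indistinguishable on this read-out. At this aromatic carbon, then, the five-membered aromatic ring is not needed to keep the number in this range: a group with no ring and one double bond outside aromatic rings serves equally, at least for this pair. No supporting data bear on why the two groups match.

Still open, as far as these compounds go, is which part of the open group carries the result, the double bond or the oxygen-bearing end. Also open, from the compounds shown here alone, is how a saturated alkyl chain, an amine or a carboxylic acid on the same aromatic carbon would read in this assay.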